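The source may hold more compounds than are shown below. What is called first, only, known or untested is meant among the compounds shown, and "the series" means these compounds.

In a functional assay on OVCAR-3 cells (Homo sapiens) for cytotoxicity, read by sulforhodamine B assay (on this read-out lower numbers stand for higher toxicity in this test and higher numbers for lower toxicity in this test), compound 3 `CC1=CC[C@@H]([C@@](C)(O)CCCC(C)(C)NC(=S)N/N=C\c2cccc([N+](=O)[O-])c2)CC1` gives only a limit, > 100000 nM, and not a number. Two close relatives do give numbers: compound 1 `CC1=CC[C@@H]([C@@](C)(O)CCCC(C)(C)NC(=S)N/N=C\c2ccc(C)cc2)CC1` reads 45300 nM, and compound 2 `CC1=CC[C@@H]([C@@](C)(O)CCCC(C)(C)NC(=S)N/N=C\c2ccccc2[N+](=O)[O-])CC1` reads 41900 nM. The step between those two is a 1.1-fold lower number from compound 1 to compound 2 (0.03 log units; within the scatter).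

Compound 4 `CC1=CC[C@@H]([C@@](C)(O)CCCC(C)(C)NC(=S)N/N=C\c2ccc(Cl)cc2)CC1` has not been measured yet. It differs from compound 3 by a single change, 4-chlorophenyl in place of 3-nitrophenyl on a carbon with a double bond to nitrogen.

Among the measured compounds shown here, two measured steps bear on this change, since both end on the 3-nitrophenyl group. They are an at least 2.2-fold higher number from compound 1 to compound 3 (0.34 log units; beyond the scatter) and an at least 2.3-fold higher number from compound 2 to compound 3 (0.37 log units; beyond the scatter). Leaving that group may therefore bring the number down by a similar modest amount. Compound 1, at 45300 nM, is the nearest guide, as its 4-methylphenyl group differs from 4-chlorophenyl only in the group on the ring.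

The expected change is an at least 2.2-fold lower number from compound 3 to compound 4 (0.34 log units; beyond the scatter), towards a lower number and so higher toxicity. For compound 4 the estimated value is 45000 nM, within an expected range of 20000 nM to 100000 nM.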

Compound 4, concentration lethal to 50% of the cells: 40600 nM
Estimate against measurement, compound 4: 1.1-fold (0.04 log units) above; the measured number falls inside the stated range.
By their numbers in this assay, from the lowest: compounds 4, 2 and 1 (each within the scatter of the next). At a limit, above all of these: compound 3.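

In this assay, replacing 3-nitrophenyl with 4-chlorophenyl gives an at least 2.4-fold lower number from compound 3 to compound 4 (0.39 log units; beyond the scatter), so a third group, this one carrying chlorine, now reads clearly lower than compound 3. The true size of this step stays unknown because compound 3 gives only a limit and not a number: the limit of > 100000 nM in this assay, at which 1 of the 4 values shown sits. Chloro and methyl on the ring cannot be told apart, with a 1.1-fold lower number from compound 1 to compound 4 (0.05 log units; within the scatter), and neither can 4-chlorophenyl and 2-nitrophenyl, with a 1.0-fold lower number from compound 2 to compound 4 (0.01 log units; within the scatter), so among these four compounds only compound 3 stands apart.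

Going by these compounds, with a single group on the ring reading apart from the others, it remains open how far that difference extends to other groups on the ring. On these data alone, whether an amine or a carboxylic acid there would match compounds 1, 2 and 4 or compound 3 also remains open.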